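The source may hold more compounds than are shown below. What is called first, only, known or untested is meant among the compounds shown, and "the series" means these compounds.

Going by the values given here, compound 2 `COc1cccc(-n2cc(COc3c(/C=C\C(=O)O)ccc(OC)c3CC=C(C)C)nn2)c1` is the only compound here with a number to its name: in a functional assay on A549 cells (Homo sapiens) for cytotoxicity, read by MTT assay, with a stated time of 24 h (on this read-out higher numbers stand for weaker inhibition and lower numbers for stronger inhibition), compound 2 gives 42700 nM, a weak effect. Compound 1 `COc1ccc(/C=C\C(=O)O)c(OCc2cn(-c3ccccc3F)nn2)c1CC=C(C)C` shares the same core, but in this assay compound 1 gives "not determined" (no result reported), so no result is at hand for it. Compound 3 `COc1ccc(/C=C\C(=O)O)c(OCc2cn(-c3ccccc3)nn2)c1CC=C(C)C` differs from compound 2 by hydrogen in place of methoxy on an aromatic carbon, in words hydrogen in place of methoxy on an aromatic carbon. Among the compounds with values here, no measured pair in this set shows what such a change does, so the expected shift a 1.1-fold higher number from compound 2 to compound 3 (0.02 log units; within the scatter) is small and should stay within the usual scatter. Compound 3 is therefore expected to give about 45000 nM in this assay, with a likely range from 15000 nM to 130000 nM.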

Compound 3, half-maximal inhibitory concentration: 40500 nM
Compound 3: the middle estimate sits 1.1-fold (0.05 log units) above what was measured; the measured number falls inside the stated range.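

Swapping 3-methoxyphenyl for phenyl gives a 1.1-fold lower number from compound 2 to compound 3 (0.02 log units; within the scatter) in this assay and so stays within the scatter. The methoxy group at this place on the aromatic ring can therefore go without a reading that stands apart, and the activity in this pair does not depend on it. Nothing measured here speaks to why the two compounds read alike.

As far as these compounds go, whether an amine or a trifluoromethyl group at this place would move the number remains open. Steps to compound 1 cannot be read, so the effect of its fluorine also remains unknown.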